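This account rests on a few compounds, and the source may have more. Where it says the series, first, only, none or still open, it means among the compounds named here.

Measured so far in an ADME assay on microsomes from liver (Mus musculus, strain CD-1) for metabolic stability, with a stated time of 1 h; a lower number here means that less of the compound is left, a higher number that more of the compound is left:
compound 1 `O=[N+]([O-])c1cn2c(n1)OC[C@H](OCc1ccc(-c3ccc(OC(F)(F)F)cc3Cl)cc1)C2` — 85%
compound 2 `CC1(COc2ccc(OC(F)(F)F)cc2)CCn2nc([N+](=O)[O-])nc2O1` — 91%

Compound 1 and compound 2 sit close to each other in this assay; the gap between them lies within the usual scatter. Compound 3 `O=[N+]([O-])c1cn2c(n1)OC[C@H](OCc1ccc(-c3ccc(C(F)(F)F)cc3Cl)cc1)C2` differs from compound 1 in one place: trifluoromethyl in place of trifluoromethoxy on an aromatic carbon. Among the measured compounds shown here, no pair of measured compounds shows this particular change, so there is no step to lean on. Compound 1 is expected to hold, with the step from compound 1 to compound 3 estimated as a number 2 percentage points higher from compound 1 to compound 3 (within the scatter), no change beyond the scatter. Because compound 1 gives 85%, compound 3 is estimated at 87%, in the range 75% to 97%.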

Compound 3, percent of the compound remaining in the Mus musculus assay: 76%
Beside the measured number, compound 3's estimate is 11 percentage points above it, within the range that was stated.
By their numbers in the Mus musculus assay, from the lowest: compounds 3, 1 and 2 (each within the scatter of the next, the first and the last beyond it).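

In the Mus musculus assay, trifluoromethyl in place of trifluoromethoxy on this aromatic carbon gives a number 9 percentage points lower from compound 1 to compound 3 (within the scatter), so this change at this place does not move the read-out beyond the scatter. In a physicochemical assay for solubility, read by HPLC, measured as kinetic solubility, with a stated time of 15 min (on this read-out higher numbers stand for higher solubility and lower numbers for lower solubility), compound 1 gives < 0.1 ug/mL, which is a limit of the assay. In the physicochemical assay, compound 3 gives < 0.1 ug/mL, also a limit, so the step between the two cannot be read: the limit of < 0.1 ug/mL in the physicochemical assay, at which 2 of the 2 values shown sit.

The compounds shown leave open how an amine or a carboxylic acid at this place would read in the physicochemical assay. They also leave open whether such a group would hold the number in the Mus musculus assay.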